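Rhodanine amides: 3-methylbenzyl in place of 4-methoxybenzyl

The source may report more compounds than this note shows. Statements on the series, on what has been measured and on what is new or still open speak of the compounds shown alone.

Measured so far in a functional assay on REH cells (Homo sapiens) for cytotoxicity, read by MTT assay, with a stated time of 72 h; a higher number here means a weaker inhibitor, a lower number a stronger inhibitor:
Compound 1 `O=C(CN1C(=O)/C(=C/c2ccc(-c3ccc(Cl)cc3)o2)SC1=S)NCc1ccc(C(F)(F)F)cc1`: 170000 nM
Compound 2 `COc1ccc(CNC(=O)CN2C(=O)/C(=C/c3ccc(-c4ccc(Cl)cc4)o3)SC2=S)cc1`: 44000 nM
Compound 3 `CCCCCCNC(=O)CN1C(=O)/C(=C/c2ccc(-c3ccc(Cl)cc3)o2)SC1=S`: 55000 nM

Compound 2 sits at the low end of the three numbers, but the step of a 1.3-fold higher number from compound 2 to compound 3 (0.10 log units; within the scatter) is within the scatter, so compound 2 and compound 3 are not separated by this assay. Compound 1 stands apart: the step of a 3.9-fold lower number from compound 1 to compound 2 (0.59 log units; beyond the scatter) and the step of a 3.1-fold lower number from compound 1 to compound 3 (0.49 log units; beyond the scatter) are both beyond the scatter, both modest.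

Compound 4 `Cc1cccc(CNC(=O)CN2C(=O)/C(=C/c3ccc(-c4ccc(Cl)cc4)o3)SC2=S)c1` has not yet been measured. It differs from compound 2 by 3-methylphenyl in place of 4-methoxyphenyl on a saturated chain carbon bound to an amide-type nitrogen.

The measured steps bearing on this change both concern the group on the saturated chain carbon bound to the amide-type nitrogen. Exchanging the 4-methoxyphenyl of compound 2 for a pentyl chain in compound 3 gave a step within the scatter, whereas the 4-(trifluoromethyl)phenyl of compound 1 gave the clearly higher number. A 3-methylphenyl lacks the hydrogen-bond acceptor of compound 2 and the trifluoromethyl of compound 1; the number for compound 4 is therefore expected to land near compound 2 and compound 3, with a modest drift upward possible. The step of a 1.4-fold higher number from compound 2 to compound 4 (0.13 log units; within the scatter) is the expected outcome in this assay. Compound 4 is estimated at 60000 nM, within 25000 nM to 150000 nM.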

Compound 4, half-maximal inhibitory concentration: 53000 nM
Beside the measured number, compound 4's estimate is 1.1-fold (0.05 log units) above it, within the range that was stated.
By their numbers in this assay, from the lowest: compounds 2, 4 and 3 (each within the scatter of the next); then compound 1.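

In this assay, the step of a 1.2-fold higher number from compound 2 to compound 4 (0.08 log units; within the scatter) shows that 3-methylphenyl can stand in place of 4-methoxyphenyl on the saturated chain carbon bound to the amide-type nitrogen without the assay separating the pair, even though the entering group counts no hydrogen-bond acceptor. With the step of a 1.0-fold lower number from compound 3 to compound 4 (0.02 log units; within the scatter) also within the scatter, the group at this place can be a 3-methylphenyl or a pentyl without the assay telling them apart, while the step of a 3.2-fold lower number from compound 1 to compound 4 (0.51 log units; beyond the scatter) lies beyond the scatter and leaves the 4-(trifluoromethyl)phenyl group apart from all three others. No supporting data accompany these numbers to account for any of these steps.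

This step changes the group on the aromatic ring and its place together, so the compounds shown leave open whether 4-methylphenyl or 3-methoxyphenyl would read the same as the two groups compared here. They also leave open how an amine, a carboxylic acid or a longer chain at this place would read in this assay.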